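Ethyl for Methyl on the Aryl Amine of a Sulfonamide Urea

This account rests on a few compounds, and the source may have more. Where it says the series, first, only, none or still open, it means among the compounds named here.

Compound 1 `Cc1ccccc1OS(=O)(=O)c1ccc(NC(=O)NCCCCl)cc1` gives 27000 nM in a functional assay on MCF7 cells (Homo sapiens) for cytotoxicity, read by sulforhodamine B assay, with a stated time of 48 h; a higher number here means a weaker inhibitor, a lower number a stronger inhibitor.
Compound 2 `CCc1ccccc1OS(=O)(=O)c1ccc(NC(=O)NCCCCl)cc1` gives 15000 nM in this assay.
Compound 3 `CCNC(=O)Nc1cccc(S(=O)(=O)Nc2ccccc2C)c1` gives 108000 nM in this assay.

Compounds 1 and 2 differ in one place: methyl in place of hydrogen on a saturated chain carbon bound to an aromatic carbon This change produced a 1.8-fold lower number from compound 1 to compound 2 (0.26 log units; within the scatter), so the two numbers cannot be told apart with confidence. Compound 3 has the highest number of the three; its gap to compound 1 is beyond the scatter, as is its larger gap to compound 2. The difference between the core of compound 3 and the core of compound 1 is not broken down here.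

Compound 4 `CCNC(=O)Nc1cccc(S(=O)(=O)Nc2ccccc2CC)c1` has not been measured in this assay. It stands to compound 3 exactly as compound 2 stands to compound 1: methyl in place of hydrogen on a saturated chain carbon bound to an aromatic carbon The place of the change is the same in both pairs, so this is the same change made on a different core.

Among the measured compounds shown here, since the only measured instance of this change, from compound 1 to compound 2, moved the number by an amount within the scatter, it is expected that the step from compound 3 to compound 4 will be of similar modest size, a 1.5-fold lower number from compound 3 to compound 4 (0.19 log units; within the scatter), in this assay. Whether a change that was small on one core carries over to another is not shown by these three compounds, so the range is kept wide. Compound 4 is therefore estimated to give 70000 nM in this assay, with the expected value lying between 35000 nM and 150000 nM.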

Compound 4, half-maximal inhibitory concentration: 48000 nM
Compound 4: middle estimate off by 1.5-fold (0.16 log units), on the high side, within the range that was stated.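

On the second core, the change from 2-methylphenyl to 2-ethylphenyl gives a 2.3-fold lower number from compound 3 to compound 4 (0.35 log units; beyond the scatter) in this assay, a modest step. Among the compounds shown here, although only this step lies beyond the scatter, the two steps cannot be told apart, so the change carries over between these two cores with a size that stays the same within the scatter: the same change on two cores in this assay, a 1.8-fold lower number (0.26 log units; within the scatter) from compound 1 to compound 2 and a 2.3-fold lower number (0.35 log units; beyond the scatter) from compound 3 to compound 4, 1.3-fold (0.10 log units) apart, within the scatter of two such steps. This is a result from two pairs in a single cytotoxicity read-out on one cell line, so it does not show that the step would keep its size on any further core, nor does it explain why the step has this size.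

The compounds shown leave open whether a longer chain such as propyl, or a branched group such as isopropyl, on a saturated chain carbon bound to an aromatic carbon would extend the step or end it. They also leave open whether the same methyl for hydrogen change would hold its size on a core carrying an amine or a carboxylic acid.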